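The compounds below may be only part of what the source reports. "The series", "measured", "known", "first", "only" and "open" are said of these compounds alone.

Measured compounds:
- compound 1 `O=C1CSC(c2c(Cl)cccc2Cl)N1CCN1CCCCC1`: 32%
- compound 2 `O=C1CSC(c2cccc(O)c2)N1CCN1CCCCC1`: 100%
- compound 3 `O=C1CSC(c2ccc(F)cc2)N1CCN1CCCCC1`: 52%

All three share one core and differ only in the aromatic group on a saturated ring carbon, and all were read in an ADME assay on Vero cells (Chlorocebus sabaeus) for cytotoxicity, read by neutral red uptake, tested at 394 ug/mL; on this read-out higher numbers stand for a weaker effect at the one concentration tested and lower numbers for a stronger effect. Among these three numbers compound 3 stands second highest: compound 1 gives 32%, a lower number, beyond the scatter, while compound 2 gives 100%, the highest number and the one furthest from compound 3.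

The compound not yet measured is compound 4 `O=C1CSC(c2ccccc2Cl)N1CCN1CCCCC1`. The change from compound 3 is 2-chlorophenyl in place of 4-fluorophenyl on a saturated ring carbon.

Among the measured compounds shown here, only one measured step touches this same place on the core: a number 48 percentage points lower from compound 2 to compound 3 (beyond the scatter), a large move. For the measured compounds named here, there is no measured step between compound 1, which carries 2,6-dichlorophenyl, and compound 3; their values simply show compound 1 lower than compound 3 in this assay. Taking compound 1 with its 32% as the nearest comparison, compound 4 is expected to land somewhat lower than compound 3, a step of a number 10 percentage points lower from compound 3 to compound 4 (within the scatter), small enough that it may fall within the scatter. The estimate for compound 4 is therefore 42%, with a range from 22% to 65%.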

Compound 4, a percentage reported as activity, at one concentration (the size of the read-out at that concentration, not a potency): 31%
For compound 4 the middle estimate is 11 percentage points above the measured one; the range from low to high includes it.
By their numbers in this assay, from the lowest: compounds 4 and 1 (each within the scatter of the next); then compound 3; then compound 2.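

In this assay, a number 21 percentage points lower from compound 3 to compound 4 (beyond the scatter) shows that the two halogen-bearing aromatic groups are not interchangeable on this saturated ring carbon: 2-chlorophenyl and 4-fluorophenyl give readings separated by more than the scatter, even though they match in heavy-atom count and in hydrogen-bond donors and acceptors. Replacing 3-hydroxyphenyl with 2-chlorophenyl gives a larger move than the earlier fluorine-bearing change did, a number 69 percentage points lower from compound 2 to compound 4 (beyond the scatter), which widens the measured span at this position. The new compound also allows a direct test of the second chlorine of the 2,6-dichlorophenyl group: a number 1 percentage points lower from compound 1 to compound 4 (within the scatter) lies within the scatter, so hydrogen in place of that chloro leaves no measurable difference in this read-out.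

Nothing available explains why these aromatic groups separate as they do. On these data alone, compound 3 and compound 4 differ in both the halogen and its place on the aromatic ring, so these two changes remain tangled, and it remains open how an aromatic ring carrying a methyl, a methoxy or an amine would read here.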